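The source may hold more compounds than are shown below. What is called first, only, known or untested is meant among the compounds shown, and "the series" means these compounds.

Working notes on the series. For the measured compounds named here, compound 1 `C/C(C(=O)NC1CC1)=C(\C)c1ccc(Br)cc1` carries a bromo on an aromatic carbon; in a functional assay on the whole organism (strain Icem-CET (SPF Caw)) for inhibition, with Mus musculus as the target, with a stated time of 30 min (a higher number here means that more compound is needed for the effect, a lower number that less compound is needed), compound 1 gives 52.4 mg/kg, the highest of the three numbers so far. Compound 2 `C#CCNC(=O)/C(C)=C(\C)c1ccc(Br)cc1` keeps the bromo but differs from compound 1 in more than one place, and the difference between the two cores is not broken down here. In this assay compound 2 gives 18.4 mg/kg, a number that lies lower than that of compound 1 by more than the scatter. Compound 3 `C#CCNC(=O)/C(C)=C(\C)c1ccc(Cl)cc1` is the chloro counterpart of compound 2; in this assay compound 3 gives 10.6 mg/kg. Going by the values given here, the single change from compound 2 to compound 3 is chloro in place of bromo on an aromatic carbon, and it produced a 1.7-fold lower number from compound 2 to compound 3 (0.24 log units; within the scatter), so the two are not distinguished by this measurement.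

Compound 4 `C/C(C(=O)NC1CC1)=C(\C)c1ccc(Cl)cc1` is not yet measured. It stands to compound 1 as compound 3 stands to compound 2: the change is chloro in place of bromo on an aromatic carbon, the same change at the same described place, and it occurs in two pairs among the compounds shown. Among the compounds with values here, only one of those pairs is measured, so the expectation rests on a single instance. A step of similar size is expected from compound 1 to compound 4, namely a 1.5-fold lower number from compound 1 to compound 4 (0.16 log units; within the scatter), because the measured pair gave a 1.7-fold lower number from compound 2 to compound 3 (0.24 log units; within the scatter). Compound 4 is therefore expected to give about 36 mg/kg in this assay, with a likely range from 20 mg/kg to 70 mg/kg.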

Compound 4, dose for half-maximal effect: 36.3 mg/kg
The estimate for compound 4 lay 1.0-fold (0.00 log units) below the measured number; the measured number falls inside the stated range.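

On the core of compound 1, chloro in place of bromo on an aromatic carbon gives a 1.4-fold lower number from compound 1 to compound 4 (0.16 log units; within the scatter) in this assay, so compound 1 and compound 4 are not distinguished by this measurement. Set beside the same change on the core of compound 2, the new step agrees with the earlier one: the same change on two cores in this assay, a 1.7-fold lower number (0.24 log units; within the scatter) from compound 2 to compound 3 and a 1.4-fold lower number (0.16 log units; within the scatter) from compound 1 to compound 4, 1.2-fold (0.08 log units) apart, within the scatter of two such steps. This shows that, across these two cores, the exchange of bromo for chloro carries over without a detectable difference between the cores; it does not show that the exchange has any real effect on either core, as both steps lie within the scatter, and two cores give no basis for extending the result to others in the series.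

The compounds shown cover only bromo and chloro at this place, para to a large group, so it stays open whether fluoro, methoxy, trifluoromethyl or a plain hydrogen there would give a step beyond the scatter. Also open, from the compounds shown here alone, is whether the agreement between cores would hold with a longer chain or an amine in place of the amide substituents carried by compound 1 and compound 2.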